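This account rests on a few compounds, and the source may have more. Where it says the series, first, only, none or still open, it means among the compounds named here.

The compounds share one core, seen in compound 3 `COc1cc(OC)c2c(=O)cc(C(=O)Nc3ccc(Oc4cccnc4)cc3)[nH]c2c1`, and differ only in the group on the outer ring of the anilide. Compound 1 `COc1cc(OC)c2c(=O)cc(C(=O)Nc3ccc(C4CCCCC4)cc3)[nH]c2c1` carries a cyclohexyl group there; in a functional assay on UoC-B1 cells (Homo sapiens) for antiproliferative activity, with a stated time of 72 h (on this read-out lower numbers stand for an effect already at smaller amounts and higher numbers for an effect only at larger amounts of compound), compound 1 gives "not determined" (no result reported), so no result is reported for it. Compound 2 `COc1cc(OC)c2c(=O)cc(C(=O)Nc3ccc(N4CCN(C)CC4)cc3)[nH]c2c1` carries a 4-methylpiperazin-1-yl group. For compound 2 this assay reports only a limit, > 19800 nM, and not a number. Among the compounds with values here, compound 3 carries a (pyridin-3-yl)oxy group, and in this assay compound 3 gives 27700 nM, the only plain number among the three. The step that the limit leaves unreadable from compound 2 to compound 3 cannot be sized because the limit of > 19800 nM in this assay, at which 1 of the 3 values shown sits, hides where compound 2 truly lies. Compound 4 `COc1cc(OC)c2c(=O)cc(C(=O)Nc3ccc(-n4cccc4)cc3)[nH]c2c1` is not yet measured; it differs from compound 3 in one place: 1H-pyrrol-1-yl in place of (pyridin-3-yl)oxy on an aromatic carbon. No measured step bears directly on this exchange, and the single step shown is unreadable, so no direction can be taken from it. The expected step is a 1.1-fold lower number from compound 3 to compound 4 (0.04 log units; within the scatter), estimated to lie within the usual scatter. The estimate for compound 4 in this assay is 25000 nM, expected between 8000 nM and 80000 nM.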

Compound 4, half-maximal effective concentration: 51800 nM
Compound 4: the middle estimate sits 2.1-fold (0.32 log units) below what was measured, within the range that was stated.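

Within the data shown here, this is the first step at this position that can be read: in this assay, putting 1H-pyrrol-1-yl in place of (pyridin-3-yl)oxy gives a 1.9-fold higher number from compound 3 to compound 4 (0.27 log units; within the scatter). The exchange swaps a six-membered aromatic ring for a five-membered one and removes the oxygen, yet compound 3 and compound 4 cannot be told apart in this read-out, since the step lies within the usual scatter of repeated measurements. The steps from compound 2 cannot be read, and this holds for both compound 3 and compound 4, because compound 2 has only a limit and not a number: the limit of > 19800 nM in this assay, at which 1 of the 4 values shown sits.

The compounds shown leave open whether a different kind of group at this position, such as a carboxylic acid, a primary amine or a longer alkyl chain, would shift the number beyond the scatter. They also leave open whether changes on the shared core itself would do so.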